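Coumarin-triazole ethers: aryl swap at the benzyl ether

This account rests on a few compounds, and the source may have more. Where it says the series, first, only, none or still open, it means among the compounds named here.

Measured so far in a functional assay on MCF7 cells (Homo sapiens) for antiproliferative activity, read by MTT assay, with a stated time of 48 h; a lower number here means a stronger inhibitor, a higher number a weaker inhibitor:
- compound 1 `O=c1cc(-n2cc(CNc3ccccc3)nn2)c2cc(Br)ccc2o1` — > 50000 nM
- compound 2 `COC(=O)c1ccccc1OCc1cn(-c2cc(=O)oc3ccc(Br)cc23)nn1` — 34100 nM
- compound 3 `O=c1cc(-n2cc(COc3ccccc3Br)nn2)c2cc(Br)ccc2o1` — 28900 nM

The value of compound 1 is a limit of the assay, not a number (the limit of > 50000 nM in this assay, at which 1 of the 3 values shown sits). Among the two numbers given, compound 3 holds the lowest; compound 2 sits nearest, and the gap a 1.2-fold lower number from compound 2 to compound 3 (0.07 log units; within the scatter) is within the scatter. The step of an at least 1.7-fold lower number from compound 1 to compound 3 (0.23 log units; that floor lies within the scatter) rests on a limit and cannot be sized beyond its floor.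

Compound 4 `O=c1cc(-n2cc(COc3ccc(F)cc3)nn2)c2cc(Br)ccc2o1` differs from compound 3 by 4-fluorophenyl in place of 2-bromophenyl on an oxygen on a saturated carbon. Neither measured step touches this place: the step from compound 1 to compound 3 changes the linking atom, the step from compound 2 to compound 3 changes a substituent on the aryl ring. Within the data shown here, no measured step therefore bears directly on the aryl swap, and no shift beyond the scatter is expected in this assay.

Compound 4 is estimated at 30000 nM, between 12000 nM and 75000 nM. The expected step of a 1.0-fold higher number from compound 3 to compound 4 (0.02 log units; within the scatter) is thus essentially none, with the upper end near the assay limit.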

Compound 4, half-maximal inhibitory concentration: 7000 nM
The estimate for compound 4 lay 4.3-fold (0.63 log units) above the measured number; measured number outside the range, below it.
By their numbers in this assay, from the lowest: compound 4; then compounds 3 and 2 (each within the scatter of the next). At a limit, above all of these: compound 1.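

In this assay, among these compounds, the aryl group on the ether oxygen proves to be a place that responds: 4-fluorophenyl in place of 2-bromophenyl gives a 4.1-fold lower number from compound 3 to compound 4 (0.62 log units; beyond the scatter), the only step between two actual numbers that lies beyond the scatter. With the same aryl swap in place, the comparison with the anilino compound now reads an at least 7.1-fold lower number from compound 1 to compound 4 (0.85 log units; beyond the scatter), whose floor clears the scatter where the floor of the step to compound 3 did not. Compound 1 stands at a limit, not a number, so this step gives a floor only: the limit of > 50000 nM in this assay, at which 1 of the 4 values shown sits.

The swap changes the halogen and its ring position together, so the compounds shown cannot separate the two. 4-Bromophenyl and 2-fluorophenyl would divide that step, and plain phenyl would show what either halogen contributes.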